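Swapping iodo for hydrogen on compound 3

This account rests on a few compounds, and the source may have more. Where it says the series, first, only, none or still open, it means among the compounds named here.

Compound 1 `C=CCCCCOc1ccc(OC)cc1-c1cnc(OCCC=C)n1C`: 33000 nM
Compound 2 `C#CCCCCOc1ncc(-c2ccccc2OC)n1C`: 11000 nM
Compound 3 `C=CCCCCOc1ncc(I)n1C`: 84000 nM

All three values come from a functional assay on LoVo cells (Homo sapiens) for inhibition, read by colorimetric assay and MTT assay, with a stated time of 72 h; a lower number here means a stronger inhibitor, a higher number a weaker inhibitor. Compound 3, at 84000 nM, has the highest number of the three and is the weakest inhibitor, with both gaps beyond the usual scatter.

Compound 4 `C=CCCCCOc1nccn1C` has hydrogen in place of iodo on an aromatic carbon. Among the measured compounds shown here, no measured pair shows this change on its own, so the data offer only indirect guidance. Compound 1 (33000 nM) and compound 2 (11000 nM) both carry a larger aromatic group on that carbon and both have lower numbers, although they also differ from compound 3 elsewhere. With only these three compounds, this is a weak hint and not an established pattern.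

The expected step of a 1.3-fold higher number from compound 3 to compound 4 (0.12 log units; within the scatter) is small, towards a slightly weaker inhibitor, and may well stay within the scatter. For compound 4 the estimated value in this assay is 110000 nM, with an expected range of 45000 nM to 260000 nM.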

Compound 4, half-maximal inhibitory concentration: > 100000 nM
Compound 4 ended at the assay's limit (the forecaster's own chance of this, stated with the estimate: 25%); the middle value does not contradict the limit.
By their numbers in this assay, from the lowest: compound 2; then compound 1; then compound 3. At a limit, above all of these: compound 4.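

Among the compounds shown here, this pair is the first in the set to show the change from iodo to hydrogen on its own, on the aromatic carbon of the five-membered ring, and it gives an at least 1.1-fold higher number from compound 3 to compound 4 (0.07 log units; that floor lies within the scatter). The reading for compound 4 is a limit of this assay and not a number: the limit of > 100000 nM in this assay, at which 1 of the 4 values shown sits. The step is therefore only a floor: hydrogen at this position brings no measurable gain in inhibition, but the true size of the loss, if there is one, cannot be read.

Going by these compounds, what remains open is how this carbon responds to other single replacements on the same core, such as chloro, an amine or a plain phenyl ring. It is also unknown whether any of these would bring the number clearly below that of iodo.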